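The source may hold more compounds than are shown below. What is called first, only, known or untested is meant among the compounds shown, and "the series" means these compounds.

Within the data shown here, compound 1 `Nc1ccccc1NC(=O)c1ccc(Cn2cnc3c(Nc4ccc(-c5ccccn5)cc4)nc(Cl)nc32)cc1` gives 30100 nM in a functional assay on HepG2 cells (Homo sapiens) for antiproliferative activity, read by CCK-8 assay, with a stated time of 72 h (a lower number here means a stronger inhibitor, a higher number a weaker inhibitor), the highest of the two numbers measured so far. Compound 2 `CCCCn1cnc2c(Nc3cccc(Cl)c3)nc(NCOCc3ccc(C(=O)Nc4ccccc4N)cc3)nc21`, arranged differently around the shared core, gives 8660 nM in this assay, a lower number than compound 1 by a margin beyond the usual scatter. Compound 3 `Nc1ccccc1NC(=O)c1ccc(Cn2cnc3c(Nc4cccc(Cl)c4)nc(Cl)nc32)cc1` has not yet been measured and differs from compound 1 in one place: 3-chlorophenyl in place of 4-(pyridin-2-yl)phenyl on a nitrogen on an aromatic ring. Among the measured compounds shown here, no measured pair isolates this change. Compound 2 also carries the 3-chlorophenyl and gives 8660 nM. On that basis a modest downward step of a 2.0-fold lower number from compound 1 to compound 3 (0.30 log units; within the scatter) is expected. Compound 3 is estimated at 15000 nM in this assay, within 5000 nM to 45000 nM.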

Compound 3, half-maximal inhibitory concentration: 9800 nM
Beside the measured number, compound 3's estimate is 1.5-fold (0.18 log units) above it; the range from low to high includes it.
By their numbers in this assay, from the lowest: compounds 2 and 3 (each within the scatter of the next); then compound 1.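

In this assay this position on the nitrogen responds to the aryl group, with a step beyond the scatter (a 3.1-fold lower number from compound 1 to compound 3 (0.49 log units; beyond the scatter)) when 3-chlorophenyl replaces 4-(pyridin-2-yl)phenyl. Among these compounds, this is the first measured pair to isolate the change, and the group with fewer heavy atoms gives the lower number. No evidence is available on why the number moves. The swap removes the pyridine ring and adds chlorine together, so the pair cannot separate those two parts. An unsubstituted phenyl or a 3-methoxyphenyl at this position would leave open how much depends on the chlorine itself.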